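Inverting One Ring Stereocentre in a Long-Chain Amide

This account rests on a few compounds, and the source may have more. Where it says the series, first, only, none or still open, it means among the compounds named here.

Three amides share the core of compound 1 (`CCCCCCCCNC(=O)[C@@H]1CSC(c2cc(OC)c(OC)c(OC)c2)N1`) and differ in the chain on the amide nitrogen. In an ADME assay on cells (Fibroblast, Homo sapiens) for antiproliferative activity, read by sulforhodamine B assay, with a stated time of 48 h (a lower number here means a stronger inhibitor, a higher number a weaker inhibitor), compound 1 gives 20800 nM while compound 2 (`CCCCCCCCCCNC(=O)[C@@H]1CSC(c2cc(OC)c(OC)c(OC)c2)N1`) gives 6700 nM and compound 3 (`CCCCCCCCCCCCCCNC(=O)[C@@H]1CSC(c2cc(OC)c(OC)c(OC)c2)N1`) gives the lowest number of the three (2600 nM). Across these compounds the number falls as the chain lengthens, and none of them goes against this. The measured steps are modest and beyond the scatter (a 3.1-fold lower number from compound 1 to compound 2 (0.49 log units; beyond the scatter)) and (a 2.6-fold lower number from compound 2 to compound 3 (0.41 log units; beyond the scatter)), with the whole run spanning a somewhat larger one (an 8.0-fold lower number from compound 1 to compound 3 (0.90 log units; beyond the scatter)). Compound 3 therefore lies nearest to compound 2 and furthest from compound 1.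

Compound 4 (`CCCCCCCCCCCCCCNC(=O)[C@H]1CSC(c2cc(OC)c(OC)c(OC)c2)N1`) keeps the chain of compound 3 and differs from it in configuration alone (the two compounds have the same atoms and bonds; at least one stereo element is drawn with a configuration in one of them and without one in the other: 1 of 2 stereo elements differ; a stereocentre at a saturated ring carbon is drawn R in compound 3 and S in compound 4). For the measured compounds named here, none of the measured steps alters a stereocentre, so they bear on this change only as a gauge of size, and none shows what an inversion does. No direction can be argued from them, and a step within the scatter is expected, though one as large as the chain steps remains possible. The expected change is small (a 1.2-fold higher number from compound 3 to compound 4 (0.06 log units; within the scatter)). Compound 4 is estimated at 3000 nM in this assay with an expected range (1200 nM to 7500 nM).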

Compound 4, half-maximal inhibitory concentration: 4100 nM
For compound 4 the middle estimate is 1.4-fold (0.14 log units) below the measured one, within the range that was stated.
By their numbers in this assay, from the lowest: compounds 3, 4 and 2 (each within the scatter of the next, the first and the last beyond it); then compound 1.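

In this assay, for the compounds shown here, the inversion gives the first direct reading on this stereocentre, and the step stays within the scatter (a 1.6-fold higher number from compound 3 to compound 4 (0.20 log units; within the scatter)). The earlier steps all changed the chain on the amide nitrogen and lay beyond the scatter, so they could only gauge size; with the long chain held fixed, the R and S drawings at this saturated ring carbon are not told apart by this measurement, and the chain remains the only change shown here to move the number beyond the scatter. The reading rests on a single pair and needs some care in how far it is taken, because of how the two structures are drawn: the fact that one of compounds 3 and 4 is drawn with a defined configuration and the other without, at the place where they differ.

As far as these compounds go, whether the inversion is equally quiet with the shorter chains of compound 1 and compound 2 remains open, as does the part played by the second stereo element, which does not differ between compound 3 and compound 4. Also open, from the compounds shown here alone, is how either configuration would read with a longer chain on the amide nitrogen, or with a carboxylic acid in place of the amide.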